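A dimethylamino group on the shared core

This account rests on a few compounds, and the source may have more. Where it says the series, first, only, none or still open, it means among the compounds named here.

Measured in a functional assay on SK-MEL-28 cells (Homo sapiens) for inhibition; on this read-out higher numbers stand for weaker inhibition and lower numbers for stronger inhibition:
compound 1 `Oc1ccc(/C=C/c2ccc3ccccc3c2)cc1`: 4060 nM
compound 2 `Cc1ccc(/C=C/c2ccc3ccccc3c2)cc1`: > 5000 nM

Compound 2 stands at > 5000 nM, which is a limit of the assay and not a number. Compound 3 `CN(C)c1ccc(/C=C/c2ccc3ccccc3c2)cc1` carries dimethylamino in place of methyl on an aromatic carbon, para to a large group (dimethylamino in place of methyl on an aromatic carbon). Among the measured compounds shown here, the only measured step that bears on this change is an at least 1.2-fold higher number from compound 1 to compound 2 (0.09 log units; that floor lies within the scatter), with methyl in place of hydroxy on an aromatic carbon. That step does not go beyond the scatter, so no step beyond the scatter is expected in this assay, in either direction. The expected step is an at least 1.1-fold lower number from compound 2 to compound 3 (0.04 log units; that floor lies within the scatter). Compound 3 is estimated at 4500 nM, with an expected range from 1800 nM to 11000 nM.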

Compound 3, half-maximal inhibitory concentration: 3660 nM
Estimate against measurement, compound 3: 1.2-fold (0.09 log units) above; measured number inside the range.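

In this assay, compound 3 gives a real number at this place on an aromatic carbon, yet the change from methyl to dimethylamino can be read only as a floor: an at least 1.3-fold lower number from compound 2 to compound 3 (0.13 log units; that floor lies within the scatter). Against hydroxy the step is a 1.1-fold lower number from compound 1 to compound 3 (0.05 log units; within the scatter), so dimethylamino and hydroxy cannot be told apart on this read-out. Compound 2 remains the one compound held at a limit of the assay and not a number: the limit of > 5000 nM in this assay, at which 1 of the 3 values shown sits.

On these data alone, how far methyl really lies from the other two groups stays unknown. Also open, as far as these compounds go, are what a primary amine, a methoxy group or a carboxylic acid would give at this place on the shared core, and whether any group here moves the number beyond the scatter.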